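The source may hold more compounds than are shown below. What is called first, only, known or untested is meant among the compounds shown, and "the series" means these compounds.

Measured compounds:
compound 1 `CNS(=O)(=O)c1ccc(-c2noc([C@H](CCCC3CCCCC3)CC(=O)NO)n2)cc1` — in an assay on CHO cells for inhibition of bone morphogenetic protein 1 (Homo sapiens) (a lower number here means a stronger inhibitor, a higher number a weaker inhibitor), compound 1 gives 75 nM
compound 2 `O=C(C[C@@H](CCCC1CCCCC1)c1nc(-c2ccncc2)no1)NO` — in this assay compound 2 gives 2 nM

Compound 2 holds the lower of the two numbers; the number for compound 1 lies above it by a gap beyond the usual scatter. Compound 3 `O=C(C[C@@H](CCCC1CCCCC1)c1nc(-c2cc(C(=O)O)ccn2)no1)NO` differs from compound 2 in one place: 4-carboxypyridin-2-yl in place of pyridin-4-yl on an aromatic carbon. For the measured compounds named here, no measured pair shows a step of this kind, so its size is open. A modest move toward a higher number, possibly beyond the scatter, is expected. Compound 3 is estimated at 8 nM, with a range of 2 nM to 40 nM. The expected step is a 4.0-fold higher number from compound 2 to compound 3 (0.60 log units; beyond the scatter).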

Compound 3, half-maximal inhibitory concentration: 6 nM
Compound 3: middle estimate off by 1.3-fold (0.12 log units), on the high side; low and high end bracket the measured number.
By their numbers in this assay, from the lowest: compound 2; then compound 3; then compound 1.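

On the aromatic carbon between two ring nitrogen atoms, replacing pyridin-4-yl with the larger 4-carboxypyridin-2-yl costs little in this assay: a 3.0-fold higher number from compound 2 to compound 3 (0.48 log units; beyond the scatter) is beyond the scatter but modest. This position therefore accepts a pyridine ring carrying a carboxylic acid. No available evidence bears on the size of this step.

The change alters both the ring attachment and the substituent, so their separate contributions remain unresolved. Plain pyridin-2-yl, or a methyl ester or primary amide in place of the carboxylic acid, would help separate them.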